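Thiophen-3-yl for furan-2-yl at the limit of growth inhibition

The source may report more compounds than this note shows. Statements on the series, on what has been measured and on what is new or still open speak of the compounds shown alone.

In a functional assay on U-373MG ATCC cells for inhibition, with U373 MG (Homo sapiens) as the target, read by MTT assay, with a stated time of 7 days (on this read-out higher numbers stand for weaker inhibition of growth and lower numbers for stronger inhibition of growth), compound 1 `C[Si](C)(C)CCOCn1nnc2c(C(N)=O)ncn2c1=O` gives 25300 nM. Compound 2 `NC(=O)c1nc[nH]c1N/N=N/Cc1ccccc1` reads > 50000 nM, which is a limit and not a number. Compound 3 `NC(=O)c1nc[nH]c1N/N=N/Cc1ccco1` reads > 50000 nM, also a limit. Compound 3 therefore stands at the limit of > 50000 nM in this assay, at which 2 of the 3 values shown sit. Going by the values given here, the one measured step is a step that the two limits leave unreadable from compound 2 to compound 3, so it offers no size to carry forward. Compound 4 `NC(=O)c1nc[nH]c1N/N=N/Cc1ccsc1` has thiophen-3-yl in place of furan-2-yl on a saturated chain carbon bound to a double-bonded nitrogen. With no readable step to guide it, the expected step is a number no higher from compound 3 to compound 4 (the limit leaves the size open), with no shift beyond the scatter in either direction. For compound 4 the estimated value is 50000 nM, within an expected range of 25000 nM to 100000 nM.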

Compound 4, concentration for 50% growth inhibition: > 50000 nM
Compound 4: a limit, no number; the forecaster's own chance of this, stated with the estimate: 85%; the middle value sits exactly at the limit.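

Going by these compounds alone, compound 2, compound 3 and compound 4 each give a limit and not a number in this assay, so no step among them can be read. Whether phenyl, furan-2-yl and thiophen-3-yl differ at all in growth inhibition stays open, and the data stop at one shared ceiling: the limit of > 50000 nM in this assay, at which 3 of the 4 values shown sit.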